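From dimethylamino to pyrrolidin-1-yl in a growth assay

This account rests on a few compounds, and the source may have more. Where it says the series, first, only, none or still open, it means among the compounds named here.

Measured so far in an ADME assay on HUVEC cells (Homo sapiens) for antiproliferative activity, read by resazurin assay, with a stated time of 72 h; on this read-out higher numbers stand for weaker inhibition of growth and lower numbers for stronger inhibition of growth:
Compound 1 `CN(C)C1=NN(c2ccccc2)CN(c2ccccc2Cl)C1=O`: 34.5 ug/mL
Compound 2 `O=C1C(N2CCCCC2)=NN(c2ccc(Cl)cc2)CN1c1ccccc1Cl`: > 50 ug/mL, a limit of the assay

For the measured compounds named here, compound 1 gives 34.5 ug/mL, the only actual number in this assay. Compound 2 is reported only as a limit, > 50 ug/mL.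

Compound 3 `O=C1C(N2CCCC2)=NN(c2ccccc2)CN1c1ccccc1Cl` carries pyrrolidin-1-yl in place of dimethylamino on a carbon with a double bond to nitrogen. Going by the values given here, no step between measured compounds covers such a swap. No change beyond the usual scatter is expected in this assay. The expected step is a 1.1-fold lower number from compound 1 to compound 3 (0.03 log units; within the scatter). For compound 3 the estimated value is 32 ug/mL, with an expected range of 16 ug/mL to 55 ug/mL.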

Compound 3, concentration for 50% growth inhibition in the HUVEC assay: 40.9 ug/mL
For compound 3 the middle estimate is 1.3-fold (0.11 log units) below the measured one; the range from low to high includes it.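

In the HUVEC assay, replacing dimethylamino with pyrrolidin-1-yl on this carbon gives a 1.2-fold higher number from compound 1 to compound 3 (0.07 log units; within the scatter), so this position accepts the added ring without a step beyond the scatter. In a physicochemical assay for lipophilicity, read by HPLC, measured as octanol-water partition (a higher number here means a more lipophilic compound, a lower number a more polar compound), the same swap gives a number 0.40 log units higher from compound 1 to compound 3 (beyond the scatter), which the growth read-out does not follow. In the physicochemical assay compound 1 gives 3.6 and compound 3 gives 4. The change thus separates the two read-outs at this position: the measured partition coefficient of compound 1, 3.6, and of compound 3, 4, a number 0.40 log units higher (beyond the scatter)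

The compounds shown leave open how morpholin-4-yl or piperazin-1-yl would behave on this carbon. They also leave open whether any group placed here moves the HUVEC assay beyond the scatter.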